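Trifluoromethyl to methylcarbamoyl: expected solubility step

A few compounds are considered here, and "the series" means these few. Any claim that something is new, unique, unknown or untested is made for them only; others in the source may bear on it.

Going by the values given here, in a physicochemical assay for solubility, with a stated time of 4 h, at pH 7.4 (a higher number here means a more soluble compound, a lower number a less soluble compound), compound 3 (`Cc1cc(/C=C/C#N)cc(C)c1Oc1cc(Nc2ccc(C#N)cc2)c(N)cc1C(F)(F)F`) gives 0.24 ug/mL, the lowest of the three numbers so far. Compound 2 (`COC(=O)c1cc(N)c(Nc2ccc(C#N)cc2)cc1Oc1c(C)cc(/C=C/C#N)cc1C`) gives 1.3 ug/mL, and compound 1 (`CNC(=O)c1cc(N)c(Nc2ccc(C#N)cc2)cc1Oc1c(C)cc(CCC#N)cc1C`) gives 8.28 ug/mL.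

Compound 4 (`CNC(=O)c1cc(N)c(Nc2ccc(C#N)cc2)cc1Oc1c(C)cc(/C=C/C#N)cc1C`) changes one place relative to compound 3: methylcarbamoyl in place of trifluoromethyl on an aromatic carbon. Among the compounds with values here, the only measured step at this place is a 5.4-fold lower number from compound 2 to compound 3 (0.73 log units; beyond the scatter), a modest one beyond the scatter, with trifluoromethyl in place of methoxycarbonyl. Compound 1 also carries methylcarbamoyl, but its nitrile-bearing chain differs from that of compound 4, so its number transfers only loosely. Within the data shown here, no measured pair compares methylcarbamoyl directly with methoxycarbonyl.

Removing trifluoromethyl is therefore expected to give an upward step in this assay beyond the scatter, of similar size to the measured one or somewhat larger, estimated as a 10-fold higher number from compound 3 to compound 4 (1.02 log units; beyond the scatter). For compound 4 the estimated value is 2.5 ug/mL, with an expected range of 0.8 ug/mL to 8 ug/mL.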

Compound 4, solubility: 1.32 ug/mL
Beside the measured number, compound 4's estimate is 1.9-fold (0.28 log units) above it, within the range that was stated.
By their numbers in this assay, from the lowest: compound 3; then compounds 2 and 4 (each within the scatter of the next); then compound 1.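

In this assay, methylcarbamoyl in place of trifluoromethyl on this aromatic carbon gives a step beyond the scatter (a 5.5-fold higher number from compound 3 to compound 4 (0.74 log units; beyond the scatter)). Methylamino in place of methoxy on the carbonyl carbon stays within the scatter (a 1.0-fold higher number from compound 2 to compound 4 (0.01 log units; within the scatter)), so methylcarbamoyl and methoxycarbonyl cannot be told apart here, and both read clear of trifluoromethyl. A second place on the shared core also matters: 2-cyanoethenyl in place of 2-cyanoethyl on an aromatic carbon gives a modest step beyond the scatter (a 6.3-fold lower number from compound 1 to compound 4 (0.80 log units; beyond the scatter)).

On these data alone, whether a carboxylic acid or a longer amide chain on this aromatic carbon would read like methylcarbamoyl stays open, as does whether the 2-cyanoethyl step holds with trifluoromethyl in this place. No supporting measurement bears on why any of these steps occur.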